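Adding a trifluoromethyl group to compound 3

A few compounds are considered here, and "the series" means these few. Any claim that something is new, unique, unknown or untested is made for them only; others in the source may bear on it.

In a functional assay on DU-145 cells (Homo sapiens) for antiproliferative activity, read by MTT assay, with a stated time of 72 h (on this read-out higher numbers stand for weaker inhibition and lower numbers for stronger inhibition), compound 1 (`c1ccc(COc2ccccc2Nc2ncnc3cc4c(cc23)OCCOCCO4)cc1`) gives > 100000 nM as a limit of the assay and not a number. Compound 2 (`O=[N+]([O-])c1ccc(COc2ccc(Nc3ncnc4cc5c(cc34)OCCOCCO5)cc2)cc1`) also gives > 100000 nM as a limit. Among the compounds with values here, compound 3 (`c1ccc(COc2ccccc2Nc2ncnc3cc4c(cc23)OCCOCCOCCO4)cc1`) stands apart with 13900 nM as the only actual number among the three. Compound 4 (`FC(F)(F)c1ccc(COc2ccccc2Nc2ncnc3cc4c(cc23)OCCOCCOCCO4)cc1`) carries trifluoromethyl in place of hydrogen on an aromatic carbon of compound 3 (trifluoromethyl in place of hydrogen on an aromatic carbon), para to a large group, so that benzyloxy becomes (4-(trifluoromethyl)benzyl)oxy. Within the data shown here, no measured pair shows this change, and no shift beyond the scatter is expected in this assay for it. The estimated step (a 1.1-fold higher number from compound 3 to compound 4 (0.03 log units; within the scatter)) is therefore small. For compound 4 the expected value is 15000 nM within an estimated range of 4000 nM to 55000 nM in the same read-out.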

Compound 4, half-maximal inhibitory concentration: > 100000 nM
Compound 4 was reported as a limit; the forecaster's own chance of this, stated with the estimate: 15%; middle value at least 6.6-fold (0.82 log units) away from the limit.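

Among the earlier compounds, only compound 3 gave a number, and none of them showed a change on its benzyl group. In this assay, trifluoromethyl on this aromatic carbon, para to a large group, brings an at least 7.1-fold higher number from compound 3 to compound 4 (0.85 log units; beyond the scatter), so the activity of compound 3 does not survive this change at this position. The value of compound 4 is a limit of the assay, so the step gives only a lower bound on the loss: the limit of > 100000 nM in this assay, at which 3 of the 4 values shown sit.

From the compounds shown here alone, whether fluorine, a methoxy group or an amine at this position would keep the activity of compound 3 remains open.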